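Fluoro-to-hydrogen step carried from one core to another

This account rests on a few compounds, and the source may have more. Where it says the series, first, only, none or still open, it means among the compounds named here.

Compound 1 `COc1ccc2c(C(=O)/C(C#N)=C/c3c[nH]c4cc(F)ccc34)c[nH]c2c1` and compound 2 `COc1ccc2c(C(=O)/C(C#N)=C/c3c[nH]c4ccccc34)c[nH]c2c1` share a core and differ in a single place: hydrogen in place of fluoro on an aromatic carbon. In a functional assay on A549 cells (Homo sapiens) for cytotoxicity, read by WST assay, with a stated time of 48 h (on this read-out higher numbers stand for weaker inhibition and lower numbers for stronger inhibition), compound 1 gives 800 nM, and compound 2 gives 7500 nM; the step is a 9.4-fold higher number from compound 1 to compound 2 (0.97 log units; beyond the scatter).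

Compound 3 `COc1ccc(Cn2cc(/C=C(\C#N)C(=O)c3c[nH]c4cc(F)ccc34)c3ccccc32)cc1` is built on a different core; the difference between the two cores is not broken down here. In this assay compound 3 gives 36300 nM, the highest number among the three measured compounds. Compound 4 `COc1ccc(Cn2cc(/C=C(\C#N)C(=O)c3c[nH]c4ccccc34)c3ccccc32)cc1` has not yet been measured. It differs from compound 3 in one place: hydrogen in place of fluoro on an aromatic carbon. The description of the place is the same, word for word, as in the pair of compound 1 and compound 2, so the change is taken as the same change made on a second core.

Within the data shown here, only one instance of this change has been measured, and it sits on a different core, so the transfer carries uncertainty. Among the measured compounds shown here, still, the step from compound 3 to compound 4 in this assay is expected to be of similar size to the earlier one, because a 9.4-fold higher number from compound 1 to compound 2 (0.97 log units; beyond the scatter) is the sole direct precedent. The expected step is a 5.5-fold higher number from compound 3 to compound 4 (0.74 log units; beyond the scatter). Compound 4 is estimated to give about 200000 nM, with a plausible range from 50000 nM to 600000 nM; a number this high may fall at the edge of what the assay can report.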

Compound 4, half-maximal inhibitory concentration: > 50000 nM
Compound 4 ended at the assay's limit (the forecaster's own chance of this, stated with the estimate: 40%); the middle value lies beyond the limit too.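

In this assay compound 4 reads > 50000 nM, which is a limit of the assay and not a number. The change from 6-fluoro-1H-indol-3-yl to 1H-indol-3-yl on the second core therefore gives an at least 1.3-fold higher number from compound 3 to compound 4 (0.13 log units; that floor lies within the scatter), a step bounded on one side only, so it does not establish that the change raises the number on this core, nor does it fix the size of the step. The result neither confirms nor rules out that the change carries over from one core to the other at a similar size, and the series still holds only one fully readable instance of it: the same change on two cores in this assay, a 9.4-fold higher number (0.97 log units; beyond the scatter) from compound 1 to compound 2 and an at least 1.3-fold higher number (0.13 log units; that floor lies within the scatter) from compound 3 to compound 4; the limit leaves it open whether they differ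

The compounds shown leave open how the number responds on either core when chloro or methyl, rather than hydrogen, takes the place of the fluoro on that aromatic carbon. They also leave open whether a basic amine or a carboxylic acid on the chain at the ring nitrogen of the second core would bring both members of such a pair within the range the assay can report, which would allow the two steps to be compared directly.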